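Swapping 3-methoxyphenyl for 4-fluorophenyl on a shared core

This account rests on a few compounds, and the source may have more. Where it says the series, first, only, none or still open, it means among the compounds named here.

- compound 1 `CC(=O)Oc1ccc2c(c1)C(C)=CC(C)(C)N2Cc1ccccc1`: 24000 nM
- compound 2 `COc1cccc(CN2c3ccc(OC(C)=O)cc3C(C)=CC2(C)C)c1`: 29000 nM

In an ADME assay on L6 cells (Rattus norvegicus) for cytotoxicity, read by resazurin assay, with a stated time of 70 h (a lower number here means a stronger inhibitor, a higher number a weaker inhibitor), compound 2 gives 29000 nM and compound 1 gives 24000 nM. These two values lie within the usual scatter of each other, so they cannot be ranked.

The next compound is compound 3 `CC(=O)Oc1ccc2c(c1)C(C)=CC(C)(C)N2Cc1ccc(F)cc1`, which keeps the shared core. Its difference from compound 2 is this: 4-fluorophenyl in place of 3-methoxyphenyl on a saturated chain carbon bound to a nitrogen on an aromatic ring in a ring.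

Going by the values given here, only one measured step bears on the change: a 1.2-fold higher number from compound 1 to compound 2 (0.08 log units; within the scatter). That step put methoxy in place of hydrogen on an aromatic carbon, so it speaks to the methoxy group that leaves here. Among the compounds with values here, no measured compound carries 4-fluorophenyl, so that half of the change is untested. With a single step to go on, and that step inside the scatter, no step beyond the scatter is expected in this assay, in either direction.

The expected step is a 1.1-fold lower number from compound 2 to compound 3 (0.05 log units; within the scatter), which is only an estimate. For compound 3 the estimated value is 26000 nM, with an expected range from 13000 nM to 52000 nM.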

Compound 3, half-maximal inhibitory concentration: 29000 nM
Estimate against measurement, compound 3: 1.1-fold (0.05 log units) below, within the range that was stated.
By their numbers in this assay, from the lowest: compounds 1, 2 and 3 (each within the scatter of the next).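

Going by these compounds alone, until now the only comparison at this position was methoxy against hydrogen on the aromatic ring. Compound 3 adds a second kind of substituent, and in this assay fluoro in place of hydrogen on an aromatic carbon gives the reading (a 1.2-fold higher number from compound 1 to compound 3 (0.08 log units; within the scatter)), while the direct exchange of 3-methoxyphenyl for 4-fluorophenyl on the saturated chain carbon gives (no change at the digits printed from compound 2 to compound 3 (within the scatter)). All three listed rings, the unsubstituted one, 3-methoxyphenyl and 4-fluorophenyl, therefore leave the number inside the scatter, no compound of the three goes against this, and the three cannot be ranked. No measured information is available that would explain this flat result.

On these data alone, all three compounds carry an uncharged aromatic ring at this place, so it remains open whether the number would stay put with an amine or a carboxylic acid on that ring, or with a longer chain joining the ring to the nitrogen. Within the data shown here, it also remains open whether a group of that kind would produce the first step beyond the scatter in this assay at this position.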